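A few compounds are considered here, and "the series" means these few. Any claim that something is new, unique, unknown or untested is made for them only; others in the source may bear on it.

Among the measured compounds shown here, in a physicochemical assay for lipophilicity, read by mass spectrometry (on this read-out lower numbers stand for lower lipophilicity and higher numbers for higher lipophilicity), compound 1 `COc1cc2c(cc1OC)C(=O)C(C(=O)Nc1ccccc1)C2` gives 2.2 and compound 2 `CCc1ccc(NC(=O)C2Cc3cc(OC)c(OC)cc3C2=O)cc1` gives 3.11, so compound 2 holds the higher of the two numbers known so far. The next structure is compound 3 `COc1ccc(NC(=O)C2Cc3cc(OC)c(OC)cc3C2=O)cc1`, which keeps everything in compound 2 except one group: methoxy in place of ethyl on an aromatic carbon. Put simply, methoxy stands in place of ethyl on an aromatic carbon, para to a large group, so that 4-ethylphenyl becomes 4-methoxyphenyl.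

For the measured compounds named here, only one measured step bears on this change: a number 0.91 log units higher from compound 1 to compound 2 (beyond the scatter), with ethyl in place of hydrogen on an aromatic carbon. Taking the ethyl away may give back most of that modest step. Methoxy is not hydrogen, however, and no measured step yet shows what methoxy does here, so the expectation stays loose. A drop of similar size in this assay seems the most likely outcome, well beyond the scatter. The expected change is a number 0.76 log units lower from compound 2 to compound 3 (beyond the scatter). For compound 3 the estimated value is 2.35, with a range from 1.95 to 2.75.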

Compound 3, partition coefficient: 2.08
Compound 3: middle estimate off by 0.27 log units, on the high side, within the range that was stated.
By their numbers in this assay, from the lowest: compounds 3 and 1 (each within the scatter of the next); then compound 2.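

In this assay, this position on the aromatic ring responds strongly to the choice of group: replacing ethyl with methoxy gives a number 1.03 log units lower from compound 2 to compound 3 (beyond the scatter), even though the two groups have the same count of heavy atoms and differ only in that one carbon gives way to one oxygen, which adds a hydrogen-bond acceptor. The comparison with the unsubstituted ring adds a second finding, as methoxy in place of hydrogen gives a number 0.12 log units lower from compound 1 to compound 3 (within the scatter), so at this position methoxy cannot be told apart from hydrogen on this read-out, whereas ethyl stands clearly apart from both. Nothing measured here explains why two groups of equal heavy-atom count behave so differently.

On these data alone, it remains open where other groups at this position would fall relative to these three compounds, for example a propyl chain, a dimethylamino group or a carboxylic acid. As far as these compounds go, all three compounds also share one core, so it is unknown whether the same exchange of ethyl for methoxy would give a step of similar size on a different core.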